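This account rests on a few compounds, and the source may have more. Where it says the series, first, only, none or still open, it means among the compounds named here.

For the measured compounds named here, compound 2 `COc1ccc(CNc2nc3cc(N)cc(N)c3nc2-c2ccccc2)cc1OC` gives 87100 nM in a functional assay on DU-145 cells (Homo sapiens) for inhibition, read by sulforhodamine B assay, with a stated time of 48 h (a lower number here means a stronger inhibitor of growth, a higher number a weaker inhibitor of growth), the highest of the two numbers measured so far. Compound 1 `Nc1cc(N)c2nc(-c3ccccc3)c(NCc3ccc(Cl)c(Cl)c3)nc2c1` gives 33100 nM in this assay, and the step of a 2.6-fold higher number from compound 1 to compound 2 (0.42 log units; beyond the scatter) separates the two. Compound 3 `COc1cc(CNc2nc3cc(N)cc(N)c3nc2-c2ccccc2)cc(OC)c1OC` has not yet been measured. It differs from compound 2 in one place: methoxy in place of hydrogen on an aromatic carbon. Going by the values given here, no measured step concerns this exact change; the only step available, a 2.6-fold higher number from compound 1 to compound 2 (0.42 log units; beyond the scatter), exchanged the whole dichlorophenyl for dimethoxyphenyl and gave a modest rise in the number, which says little about what a third methoxy on that ring would do. A step for compound 3 that stays within the scatter of this assay is therefore expected, with no direction favoured. Compound 3 is expected to give 90000 nM in this assay, within a range from 35000 nM to 230000 nM. This amounts to an expected step of a 1.0-fold higher number from compound 2 to compound 3 (0.01 log units; within the scatter).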

Compound 3, concentration for total growth inhibition: 20000 nM
For compound 3 the middle estimate is 4.5-fold (0.65 log units) above the measured one, and the stated range ends above it.
By their numbers in this assay, from the lowest: compounds 3 and 1 (each within the scatter of the next); then compound 2.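

The added methoxy, on an aromatic carbon ortho to a methoxy group and meta to a large group, has a clear effect of its own in this assay: it gives a 4.4-fold lower number from compound 2 to compound 3 (0.64 log units; beyond the scatter) and so brings a measurable gain in growth inhibition. The earlier step, a 2.6-fold higher number from compound 1 to compound 2 (0.42 log units; beyond the scatter), exchanged the whole set of ring substituents and could not show what one group at this place contributes. This position therefore accepts a further methoxy, and the number moves in the lower direction, but no measurement given here bears on why it does so.

The compounds shown leave open whether the gain belongs to methoxy itself or would also appear with a hydroxy, an ethoxy or a chlorine at this carbon. They also leave open whether a longer chain in place of this methoxy would keep the lower number.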